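The source may report more compounds than this note shows. Statements on the series, on what has been measured and on what is new or still open speak of the compounds shown alone.

Working notes on the series

Two members of the series have numbers in a functional assay on the whole organism (strain Swiss) with Mus musculus as the target, in the maximal electroshock model, with a stated time of 1 h, at a dose of 100 mg/kg by the intraperitoneal route; on this read-out lower numbers stand for a weaker effect and higher numbers for a stronger effect at the one dose given. Compound 1 `COc1cccc(N2CCN(C(=O)C(C)N3C(=O)CCC3=O)CC2)c1` gives 0% in this assay. Compound 2 `CC(C(=O)N1CCN(c2cccc(C(F)(F)F)c2)CC1)N1C(=O)CCC1=O` gives 50% in this assay, and on the two numbers shown compound 2 stands highest; the only measured step to it is a number 50 percentage points higher from compound 1 to compound 2 (beyond the scatter).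

The next member, compound 3 `Cc1cccc(N2CCN(C(=O)C(C)N3C(=O)CCC3=O)CC2)c1`, differs from compound 2 by methyl in place of trifluoromethyl on an aromatic carbon. Within the data shown here, no measured step changes trifluoromethyl for methyl, so the only step that bears on this change is the one from compound 1 to compound 2, a number 50 percentage points higher from compound 1 to compound 2 (beyond the scatter), which shows that the group at this aromatic carbon moves the read-out strongly in this assay. Since compound 2 gives 50% and compound 1 gives 0%, and methyl is a third group rather than a return to methoxy, a fall from the number of compound 2 is expected, but its size is uncertain and could be small. The step from compound 2 to compound 3 is therefore estimated at a number 25 percentage points lower from compound 2 to compound 3 (beyond the scatter). For compound 3 the estimate in this assay is 25%, with a range from 0% to 60%.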

Compound 3, a percentage reported as activity, at one dose (the size of the read-out at that dose, not a potency): 0%
For compound 3 the middle estimate is 25 percentage points above the measured one, within the range that was stated.
By their numbers in this assay, from the lowest: compounds 1 and 3 (each within the scatter of the next); then compound 2.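

In this assay, methyl in place of trifluoromethyl on an aromatic carbon gives a number 50 percentage points lower from compound 2 to compound 3 (beyond the scatter), so the higher number of compound 2 does not follow from simply removing methoxy from this carbon. Methyl in place of methoxy gives no change at the digits printed from compound 1 to compound 3 (within the scatter), which places compound 1 and compound 3 together and leaves trifluoromethyl as the only one of the three groups at this carbon with a read-out beyond the scatter of the other two, a contrast that rests on these three compounds alone. No supporting measurement is available to account for this difference between the groups.

Whether the higher read-out is peculiar to trifluoromethyl remains open, since the compounds shown do not include a chlorine atom, a nitrile or a trifluoromethoxy group at this carbon. Also open, as far as these compounds go, are whether trifluoromethyl on another carbon of the same aromatic ring keeps the read-out of compound 2, and whether compound 1 and compound 3 would separate at a dose other than the one given.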